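Swapping One Group in an Antiproliferative Series

This account rests on a few compounds, and the source may have more. Where it says the series, first, only, none or still open, it means among the compounds named here.

Measured in a functional assay on MCF7 cells (Homo sapiens) for antiproliferative activity, read by MTT assay; a lower number here means a stronger inhibitor, a higher number a weaker inhibitor:
- Compound 1 `CC1(C)CCc2cc(C(=O)/C=C/c3ccc(OCc4cn(-c5ccc(Cl)cc5)nn4)cc3)c(O)cc2O1`: "not active" (no number reported)
- Compound 2 `COc1ccc(-n2cc(COc3ccc(/C=C/C(=O)c4cc5c(cc4O)OC(C)(C)CC5)cc3)nn2)c([N+](=O)[O-])c1`: "not active" (no number reported)
- Compound 3 `CC(=O)c1ccc(-n2cc(COc3ccc(/C=C/C(=O)c4cc5c(cc4O)OC(C)(C)CC5)cc3)nn2)cc1`: 182000 nM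

Only compound 3 has a number here, while compounds 1 and 2 gave none. Compound 4 `Cc1ccc(-n2cc(COc3ccc(/C=C/C(=O)c4cc5c(cc4O)OC(C)(C)CC5)cc3)nn2)cc1Br` differs from compound 3 in one group, with 3-bromo-4-methylphenyl in place of 4-acetylphenyl on an aromatic nitrogen. Within the data shown here, no measured pair shows what a change in this group does, so no shift beyond the scatter is expected in this assay, in either direction. Among the measured compounds shown here, the only numerical anchor is compound 3 at 182000 nM. The expected size of the change is a 1.2-fold lower number from compound 3 to compound 4 (0.08 log units; within the scatter). For compound 4 the estimated value is 150000 nM, with an expected range from 50000 nM to 400000 nM.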

Compound 4, half-maximal inhibitory concentration: "not active" (no number reported)
Compound 4 has no reported number here, so the estimate cannot be set against anything.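

Among these compounds, compound 4 has no reported number, so no step from compound 3 to compound 4 can be read. No evidence here bears on this result. In this assay, going by these compounds, the effect of exchanging 4-acetylphenyl for 3-bromo-4-methylphenyl stays open.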